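Removing the ring methyl from compound 1

A few compounds are considered here, and "the series" means these few. Any claim that something is new, unique, unknown or untested is made for them only; others in the source may bear on it.

Compound 1 `CC(C)C(CC1C(=O)NC(=O)N1C)c1ccc(-c2ccc3cccc(F)c3c2)[nH]c1=O`: 17.6 10^-6 cm/s
Compound 2 `CC(C)[C@H](C[C@H]1OC(=O)NC1=O)c1ccc(-c2ccc3cccc(F)c3c2)[nH]c1=O`: 10.3 10^-6 cm/s

In an ADME assay on MDCK cells (Canis lupus familiaris) for permeability, in the apical to basolateral direction (a lower number here means that the compound crosses the layer more slowly, a higher number that the compound crosses the layer faster), compound 1 gives 17.6 10^-6 cm/s, and compound 2 gives 10.3 10^-6 cm/s. These two values lie within the usual scatter of each other, so compound 1 stands level with compound 2.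

Compound 3 `CC(C)C(CC1NC(=O)NC1=O)c1ccc(-c2ccc3cccc(F)c3c2)[nH]c1=O` departs from compound 1 in one place: hydrogen in place of methyl on an amide-type nitrogen in a ring. In words, hydrogen takes the place of methyl on an amide-type nitrogen in a ring. For the measured compounds named here, no measured pair shows this change, so the data hold no direct precedent. Going by the values given here, the only other guide is compound 2, which carries a different group at 10.3 10^-6 cm/s. A small downward move is expected, not clearly beyond the scatter, and the expected step is a 1.8-fold lower number from compound 1 to compound 3 (0.25 log units; within the scatter). For compound 3 the estimated value is 10 10^-6 cm/s, with an expected range from 4.5 10^-6 cm/s to 19 10^-6 cm/s.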

Compound 3, apparent permeability: 17.1 10^-6 cm/s
Compound 3: the middle estimate sits 1.7-fold (0.23 log units) below what was measured; low and high end bracket the measured number.
By their numbers in this assay, from the lowest: compounds 2, 3 and 1 (each within the scatter of the next).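

In this assay the step from methyl to hydrogen on the amide-type nitrogen in a ring reads as a 1.0-fold lower number from compound 1 to compound 3 (0.01 log units; within the scatter) and lies within the scatter. For the compounds shown here, this gives the first direct reading of this change at this position, which the earlier compounds held no pair to show, and here the methyl can be replaced by hydrogen without a readable step in the number. No measurement available here explains why the step is so small.

The compounds shown leave open whether an ethyl group, a longer chain or a chain ending in a carboxylic acid on this same nitrogen would also stay within the scatter of compound 1. They also leave open whether the same step would read alike with another group on the shared core.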